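The source may hold more compounds than are shown below. What is called first, only, known or untested is meant among the compounds shown, and "the series" means these compounds.

Results in a functional assay on NCI-H460 cells (Homo sapiens) for cytotoxicity, read by MTT assay, with a stated time of 48 h; on this read-out higher numbers stand for weaker inhibition and lower numbers for stronger inhibition:

- Compound 1 `C=C1C(=O)O[C@H]2CC3=C[C@H](C/C(C)=C/[C@@H](OC(=O)c4ccc([N+](=O)[O-])cc4)[C@H]12)OC3=O`: > 10000 nM (a limit of the assay, not a number)
- Compound 2 `C=C1C(=O)O[C@H]2CC3=C[C@H](C/C(C)=C/[C@@H](OC(=O)CCCCBr)[C@H]12)OC3=O`: > 10000 nM (a limit of the assay, not a number)
- Compound 3 `C=C1C(=O)O[C@H]2CC3=C[C@H](C/C(C)=C/[C@@H](OC(=O)C4CC4)[C@H]12)OC3=O`: 3000 nM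

Compound 3 is the only one of these with a true number, and it has the strongest inhibition of the three. The other results are the limit of > 10000 nM in this assay, at which 2 of the 3 values shown sit.

The untested compound 4 `C=C1C(=O)O[C@H]2CC3=C[C@H](C/C(C)=C/[C@@H](OC(=O)/C=C/c4ccncc4)[C@H]12)OC3=O` changes one group, with 2-(pyridin-4-yl)ethenyl in place of cyclopropyl on a carbonyl carbon.

Among the measured compounds shown here, two measured steps bear on this change: an at least 3.3-fold lower number from compound 1 to compound 3 (0.52 log units; beyond the scatter) and an at least 3.3-fold lower number from compound 2 to compound 3 (0.52 log units; beyond the scatter). Both end at cyclopropyl, so losing that group has so far gone with weaker inhibition. The entering group shares an aromatic ring with the 4-nitrophenyl of compound 1, but the 4-bromobutyl of compound 2 has no such ring, so this guide is loose.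

A small move toward a higher number in this assay is therefore expected, not clearly beyond the scatter, and a result at the limit remains possible. The estimated change is a 1.7-fold higher number from compound 3 to compound 4 (0.22 log units; within the scatter). For compound 4 the expected value is 5000 nM, with an estimated range from 1500 nM to 16000 nM.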

Compound 4, half-maximal inhibitory concentration: 2100 nM
Beside the measured number, compound 4's estimate is 2.4-fold (0.38 log units) above it, within the range that was stated.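

In this assay, among the compounds shown here, the new group gives a 1.4-fold lower number from compound 3 to compound 4 (0.15 log units; within the scatter), so cyclopropyl is not the only group on this carbonyl carbon that gives a true number. An aromatic ring alone does not settle the result, as the 4-nitrophenyl group shows in an at least 4.7-fold lower number from compound 1 to compound 4 (0.67 log units; beyond the scatter), and the 4-bromobutyl chain gives an at least 4.7-fold lower number from compound 2 to compound 4 (0.67 log units; beyond the scatter). Compound 1 and compound 2 each stand at a limit of the assay, not a number, so these two steps give only a smallest size: the limit of > 10000 nM in this assay, at which 2 of the 4 values shown sit.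

Going by these compounds, what remains open is whether the ring nitrogen or the double bond of 2-(pyridin-4-yl)ethenyl matters for the number, and what a plain 2-phenylethenyl group would give on this carbonyl carbon. On these data alone, it is also open how a group carrying an amine or a carboxylic acid would fare here.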